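The source may hold more compounds than are shown below. What is called first, only, known or untested is meant among the compounds shown, and "the series" means these compounds.

Of the compounds shown here, three have been measured in an assay for binding affinity to Apoptosis regulator Bcl-2 (Homo sapiens), read by fluorescence polarization, with stated times of 30 min and 20 min, tested at 100 uM; on this read-out higher numbers stand for more inhibition at the one concentration tested (going by the name of the read-out) and lower numbers for less inhibition. Compound 1 `COc1ccc(Oc2ccccc2-c2ccsc2S(=O)(=O)N2CCN(C(=S)Nc3ccc([N+](=O)[O-])cc3)CC2)cc1OC` gives 16%. Compound 2 `O=C(Nc1ccc(F)cc1)N1CCN(S(=O)(=O)c2sccc2-c2ccccc2Oc2ccc(O)c(O)c2)CC1` gives 33%, and compound 3 `O=C(Nc1ccc([N+](=O)[O-])cc1)N1CCN(S(=O)(=O)c2sccc2-c2ccccc2Oc2ccc(O)c(O)c2)CC1` gives 33%. Among the measured compounds shown here, the one measured step, no change at the digits printed from compound 2 to compound 3 (within the scatter), leaves the read-out where it was. Compound 3 therefore stands level with compound 2, the two together at the top of the three numbers, while compound 1 lies lower by a margin beyond the scatter.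

Compound 4 `O=[N+]([O-])c1ccc(NC(=S)N2CCN(S(=O)(=O)c3sccc3-c3ccccc3Oc3ccc(O)c(O)c3)CC2)cc1` differs from compound 3 in one place: a group of 12 heavy atoms (7 carbon, 2 nitrogen, 2 oxygen, 1 sulfur; one six-membered aromatic ring of carbon only) in place of a group of 12 heavy atoms (7 carbon, 2 nitrogen, 3 oxygen; one six-membered aromatic ring of carbon only), on an amine nitrogen in a ring. The (4-nitrophenyl)carbamoyl group leaves and a group of the same size enters on the amine nitrogen in a ring. For the measured compounds named here, no measured step bears directly on this exchange; the only measured step, no change at the digits printed from compound 2 to compound 3 (within the scatter), concerns another part of the molecule and was flat. Compound 1 carries the entering group but differs elsewhere as well, so its 16% is not a direct guide. The expected step is a number 3 percentage points lower from compound 3 to compound 4 (within the scatter), within the scatter. Compound 4 is estimated to give 30%, between 14% and 46%.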

Compound 4, a percentage reported as inhibition, at one concentration (the size of the read-out at that concentration, not a potency): 31%
Compound 4: the middle estimate sits 1 percentage points below what was measured; the measured number falls inside the stated range.
By their numbers in this assay, from the lowest: compound 1; then compounds 4, 2 and 3 (each within the scatter of the next).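

In this assay, the group with sulfur in place of the (4-nitrophenyl)carbamoyl group on the amine nitrogen in a ring gives a number 2 percentage points lower from compound 3 to compound 4 (within the scatter), and the same position shows a number 2 percentage points lower from compound 2 to compound 4 (within the scatter), so neither exchange there moves the read-out beyond the scatter. With 3,4-dihydroxyphenyl in place of 3,4-dimethoxyphenyl on an oxygen on an aromatic ring, the read-out shows a number 15 percentage points higher from compound 1 to compound 4 (beyond the scatter), so the low number of compound 1 goes with that change and not with the group on the ring nitrogen. Nothing available explains these steps.

On these data alone, it remains open whether a benzyl or acetyl group on the amine nitrogen in a ring would hold the read-out at this level. As far as these compounds go, it is equally open whether a phenyl carrying a single hydroxy group or a carboxylic acid could stand in for the 3,4-dihydroxyphenyl group.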